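The source may report more compounds than this note shows. Statements on the series, on what has been measured and on what is new or still open speak of the compounds shown alone.

Measured in an assay on thoracic aorta for inhibition of Voltage-gated L-type calcium channel (Rattus norvegicus); on this read-out higher numbers stand for weaker inhibition and lower numbers for stronger inhibition: compound 1 `COC(OC)C1=C(C(=O)OC/C=C/c2ccccc2)C(c2cccc(Cl)c2)C(C(=O)O)=C(C)N1` gives 8100 nM, and compound 2 `CC1=C(C(=O)O)C(c2cccc(Cl)c2)C(C(=O)OC/C=C/c2ccccc2)=C(C#N)N1` gives 2000 nM.

Compound 1 has the higher of the two numbers. The change to compound 3 `CCC1=C(C(=O)OC/C=C/c2ccccc2)C(c2cccc(Cl)c2)C(C(=O)O)=C(C)N1` is ethyl in place of dimethoxymethyl on a double-bonded ring carbon. One measured step replaces the same dimethoxymethyl group: a 4.1-fold lower number from compound 1 to compound 2 (0.61 log units; beyond the scatter), with a cyano group entering. That step points toward a lower number, but ethyl is a different group from cyano, so the expected step is smaller and uncertain: a 2.0-fold lower number from compound 1 to compound 3 (0.31 log units; beyond the scatter) is the estimate. Compound 3 is therefore expected to give 4000 nM, roughly between 1500 nM and 12000 nM.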

Compound 3, half-maximal inhibitory concentration: 7 nM
The estimate for compound 3 lay 570-fold (2.76 log units) above the measured number; the whole stated range lies above it.
By their numbers in this assay, from the lowest: compound 3; then compound 2; then compound 1.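

Changing the group on this double-bonded ring carbon, next to the ring nitrogen, can shift the number far more than the earlier step suggested. Ethyl in place of dimethoxymethyl gives a 1200-fold lower number from compound 1 to compound 3 (3.06 log units; beyond the scatter) in this assay and ethyl in place of cyano gives a 290-fold lower number from compound 2 to compound 3 (2.46 log units; beyond the scatter) in the same test, so among these three groups ethyl gives the lowest number by a wide margin. No measurement at hand offers an explanation for steps of this size. 

Still open, as far as these compounds go, is whether ethyl is a special case. A methyl group, a longer chain such as propyl, or an amine at this place could show whether the number stays this low.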